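A few compounds are considered here, and "the series" means these few. Any claim that something is new, unique, unknown or untested is made for them only; others in the source may bear on it.

Notes on the series. Compound 1 `O=S(=O)(/C=C/c1ccccc1)Cc1ccc(Nc2ncnc3ccccc23)cc1` gives 74000 nM in a functional assay on MCF7 cells (Homo sapiens); a lower number here means a stronger inhibitor of growth, a higher number a weaker inhibitor of growth. Compound 2 `O=S(=O)(/C=C/c1ccc(F)cc1)Cc1ccc(Nc2ncnc3ccccc23)cc1` carries a 4-fluorophenyl group where compound 1 carries a phenyl group; in this assay compound 2 gives 16000 nM. That single change produced a 4.6-fold lower number from compound 1 to compound 2 (0.67 log units; beyond the scatter). Within the data shown here, on the two numbers so far compound 2 stands lowest, with compound 1 as its only neighbour at a higher number.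

Compound 3 `O=S(=O)(/C=C/c1ccc(F)cc1F)Cc1ccc(Nc2ncnc3ccccc23)cc1` differs from compound 2 by fluoro in place of hydrogen on an aromatic carbon, which read one bond further out is 4-fluorophenyl to 2,4-difluorophenyl. Among the measured compounds shown here, the one measured step that bears on this is a 4.6-fold lower number from compound 1 to compound 2 (0.67 log units; beyond the scatter), the same kind of change, a fluoro entering for a hydrogen on the same ring. A lowering step of similar or somewhat smaller size is expected for compound 3 because a 4.6-fold lower number from compound 1 to compound 2 (0.67 log units; beyond the scatter) ran that way. The expected step is a 1.8-fold lower number from compound 2 to compound 3 (0.25 log units; within the scatter). Compound 3 is estimated at 9000 nM, within 3000 nM to 30000 nM.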

Compound 3, concentration for 50% growth inhibition: > 100000 nM
Compound 3 ended at the assay's limit; the forecaster's own chance of this, stated with the estimate: 2%; at least 11-fold (1.04 log units) between middle value and limit.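

In this assay, fluoro in place of hydrogen on the aromatic carbon ortho to a large group and meta to a fluoro group gives an at least 6.2-fold higher number from compound 2 to compound 3 (0.79 log units; beyond the scatter), which runs opposite to a 4.6-fold lower number from compound 1 to compound 2 (0.67 log units; beyond the scatter), so the same kind of change on the same ring does not hold one direction across these compounds. The value of compound 3 is a limit of the assay and not a number: the limit of > 100000 nM in this assay, at which 1 of the 3 values shown sits.

Against the phenyl group, 2,4-difluorophenyl gives an at least 1.3-fold higher number from compound 1 to compound 3 (0.13 log units; that floor lies within the scatter), so the lowering seen with 4-fluorophenyl does not survive this added fluoro, while the true distance between these two compounds stays unread.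

The compounds shown leave open whether a fluoro alone on this ring carbon, without the 4-fluoro, would go the way of compound 3, and whether a methoxy or an amine there would do the same. They also give no cause for the reversal.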